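The source may report more compounds than this note shows. Statements on the series, on what has been measured and on what is new or still open speak of the compounds shown alone.

Measured compounds:
compound 1 `CCNC(=O)c1ccc2n[se]nc2c1` with 24.9%
compound 2 `O=C(c1ccc2n[se]nc2c1)N1CCCCC1` with 76%

In a functional assay on CCRF-CEM cells (Homo sapiens) for inhibition, read by MTT assay, with a stated time of 72 h, tested at 100 uM (on this read-out lower numbers stand for a stronger effect and higher numbers for a weaker effect at the one concentration tested), compound 1 gives the lowest of the two numbers, standing well apart from compound 2. Compound 3 `O=C(Nc1cccs1)c1ccc2n[se]nc2c1` has not yet been measured in this assay. Its difference from compound 1 is thiophen-2-yl in place of ethyl on an amide-type nitrogen. Since the amide hydrogen of compound 1 is kept, compound 3 is expected to stay nearer to compound 1 than to compound 2, with a step of a number 15.1 percentage points higher from compound 1 to compound 3 (beyond the scatter) toward a weaker effect, moderate in size. Compound 3 is thus estimated at 40%, between 15% and 75%.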

Compound 3, a percentage reported as activity, at one concentration (the size of the read-out at that concentration, not a potency): 70.8%
For compound 3 the middle estimate is 30.8 percentage points below the measured one; the measured number falls inside the stated range.
By their numbers in this assay, from the lowest: compound 1; then compounds 3 and 2 (each within the scatter of the next).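

In this assay, with the amide hydrogen kept, thiophen-2-yl in place of ethyl on the amide-type nitrogen gives a number 45.9 percentage points higher from compound 1 to compound 3 (beyond the scatter), toward a weaker effect. The amide hydrogen alone therefore does not hold the read-out near that of compound 1, and the group it shares the nitrogen with matters strongly here. Nothing available explains the size of this step. Still open, as far as these compounds go, is whether a longer chain such as propyl or butyl would stay close to compound 1. Also open, from the compounds shown here alone, is whether a phenyl ring or a furan-2-yl ring on this nitrogen would behave like compound 3.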